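The compounds below may be only part of what the source reports. "The series", "measured", "known", "first", "only" and "open" are said of these compounds alone.

Working notes on the series.

Compound 1 `Nc1scc(CN2CCN(c3ccc(F)cc3F)CC2)c1C(=O)c1ccc(Cl)cc1` is the reference point. In a functional assay on CHO cells with adenosine receptor A1 (Homo sapiens) as the target, read by cAMP accumulation and immunoassay, with a stated time of 6 min, tested at 1 uM (a higher number here means a weaker effect of the compound at the concentration tested, a lower number a stronger effect), compound 1 gives -66%. Compound 2 `Nc1scc(CN2CCN(c3cc(F)cc(F)c3)CC2)c1C(=O)c1ccc(Cl)cc1` carries a 3,5-difluorophenyl in place of the 2,4-difluorophenyl on the amine nitrogen in the ring, and in this assay compound 2 gives -66%. Among the measured compounds shown here, the one measured step, no change at the digits printed from compound 1 to compound 2 (within the scatter), shows that moving the two fluorines around the aromatic ring on the ring nitrogen left the read-out where it was. Compound 2 therefore stands level with compound 1 at the digits recorded, and nothing in the pair separates the two fluorophenyl patterns.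

Compound 3 `Nc1scc(CN2CCN(c3cc(F)ccc3F)CC2)c1C(=O)c1ccc(Cl)cc1` is the next member. The change from compound 2 is 2,5-difluorophenyl in place of 3,5-difluorophenyl on an amine nitrogen in a ring. For the measured compounds named here, the only step that bears on it is the earlier swap of difluorophenyl patterns, no change at the digits printed from compound 1 to compound 2 (within the scatter), which stayed within the scatter. A third arrangement of the same two fluorines on the same ring is expected to behave likewise, so the step of no change at the digits printed from compound 2 to compound 3 (within the scatter) is expected to stay within the scatter. For compound 3 in this assay the expected value is -66%, with a range from -80% to -52%.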

Compound 3, a percentage reported as activity, at one concentration (the size of the read-out at that concentration, not a potency): -59%
Estimate against measurement, compound 3: 7 percentage points below; low and high end bracket the measured number.
By their numbers in this assay, from the lowest: compounds 1, 2 and 3 (each within the scatter of the next).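

In this assay the 2,5-difluorophenyl on the amine nitrogen in the ring gives a number 7 percentage points higher from compound 2 to compound 3 (within the scatter) and a number 7 percentage points higher from compound 1 to compound 3 (within the scatter), so this third arrangement of the two fluorines separates from neither of the earlier two. Among the compounds shown here, the single pair of compounds 1 and 2 spoke for two difluorophenyl patterns only; compounds 1, 2 and 3 now show three patterns on this position reading alike within the scatter, and none of the three goes against that, though the claim reaches no further than these compounds. No measurement to hand offers an explanation for this flat read-out across the fluorine patterns.

As far as these compounds go, all three compounds carry two fluorines on the phenyl, so it stays open whether the read-out would hold with a phenyl bearing no fluorine, a single fluorine, a methoxy group or a trifluoromethyl group at this position. The read-out also comes from one concentration and is not a potency, so any difference among the three difluorophenyl patterns that would appear at other concentrations remains unresolved.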